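Swapping methoxy for nitro in a tolerated triazene

This account rests on a few compounds, and the source may have more. Where it says the series, first, only, none or still open, it means among the compounds named here.

Measured in an ADME assay on MDBK cells (Bos taurus) for cytotoxicity, read by MTT assay, with a stated time of 96 h; a lower number here means that less compound is tolerated, a higher number that more compound is tolerated:
- compound 1 `COc1ccc(/N=N/N2CCCC2)cc1`: 60000 nM
- compound 2 `Fc1ccc(F)c(/N=N/N2CCCC2)c1`: > 100000 nM, a limit
- compound 3 `Clc1cccc(/N=N/N2CCCCC2)c1`: > 100000 nM, a limit

Among the compounds with values here, compound 1 holds the only actual number, 60000 nM. The rest of the set stands at the limit of > 100000 nM in this assay, at which 2 of the 3 values shown sit.

Compound 4 `O=[N+]([O-])c1ccc(/N=N/N2CCCC2)cc1` has not yet been measured. It carries nitro in place of methoxy on an aromatic carbon. Within the data shown here, no measured pair here shows a change of this kind, so the data give no size for it. The expectation in this assay is therefore no shift beyond the scatter, in either direction. The expected change is no change at the digits printed from compound 1 to compound 4 (within the scatter). For compound 4 the estimated value is 60000 nM, with an expected range from 20000 nM to 100000 nM.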

Compound 4, half-maximal cytotoxic concentration: > 100000 nM
Compound 4 gave a limit, no number; the forecaster's own chance of this, stated with the estimate: 40%; at least 1.6-fold (0.22 log units) between middle value and limit.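

In this assay, nitro in place of methoxy on an aromatic carbon gives an at least 1.6-fold higher number from compound 1 to compound 4 (0.22 log units; that floor lies within the scatter). Within the data shown here, this is the first view of a change at this place on the ring, and swapping methoxy for nitro brings no drop in the number. The value for compound 4 is a limit, not a number, and it joins the others there: the limit of > 100000 nM in this assay, at which 3 of the 4 values shown sit.

On these data alone, the true size of the gap between compound 1 and compound 4 stays open. So does the effect of an amine or a carboxylic acid at this same place.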